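Allyl ester of compound 1: expected Bcl-2 binding

The compounds below may be only part of what the source reports. "The series", "measured", "known", "first", "only" and "open" are said of these compounds alone.

Measured compounds:
compound 1 `C[C@@H](C(=O)O)N1C(=O)/C(=C/c2ccc(Br)cc2)SC1=S`, 115000 nM
compound 2 `O=C(O)CC[C@@H](C(=O)O)N1C(=O)/C(=C/c2ccc(Br)cc2)SC1=S`, 320000 nM
compound 3 `CC(C)C[C@@H](C(=O)O)N1C(=O)/C(=C/c2ccc(Br)cc2)SC1=S`, 7430 nM

In an assay on isolated protein for displacement of a labelled ligand from Apoptosis regulator Bcl-2 (Homo sapiens), read by fluorescence polarization (on this read-out higher numbers stand for weaker inhibition and lower numbers for stronger inhibition), compound 1 gives 115000 nM, the second highest of the three numbers. Its nearest neighbour is compound 2, reached by a 2.8-fold higher number from compound 1 to compound 2 (0.44 log units; beyond the scatter); its furthest is compound 3, reached by a 15-fold lower number from compound 1 to compound 3 (1.19 log units; beyond the scatter). The step of a 43-fold lower number from compound 2 to compound 3 (1.63 log units; beyond the scatter) spans the whole measured range.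

Compound 4 `C=CCOC(=O)[C@H](C)N1C(=O)/C(=C/c2ccc(Br)cc2)SC1=S` differs from compound 1 by allyl in place of hydrogen on an oxygen next to a carbonyl group; the same difference, cut one bond further out, reads carboxy to allyloxycarbonyl.

For the measured compounds named here, none of the measured steps touches this oxygen: all three change the substituent on the saturated chain carbon two bonds along the chain from the amide-type nitrogen in the ring and the carbonyl carbon, leaving the carboxy itself in place. Those steps show the assay responds strongly to what sits on that chain, from modest to large, in both directions. For compound 4 there is no measured guide, so only a cautious expectation is possible.

Compound 4 is therefore estimated at 70000 nM, within 15000 nM to 300000 nM, which corresponds to an expected step of a 1.6-fold lower number from compound 1 to compound 4 (0.22 log units; within the scatter) from compound 1, with wide uncertainty.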

Compound 4, inhibition constant: 192000 nM
Estimate against measurement, compound 4: 2.7-fold (0.44 log units) below; measured number inside the range.
By their numbers in this assay, from the lowest: compound 3; then compounds 1, 4 and 2 (each within the scatter of the next, the first and the last beyond it).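

Compound 4 is the only compound shown in which the carboxy itself is altered, and it gives the first reading at this oxygen: in this assay, allyl in place of hydrogen gives a 1.7-fold higher number from compound 1 to compound 4 (0.22 log units; within the scatter), so the two numbers cannot be told apart. On the core of compound 1, then, the hydrogen of the carboxy can give way to allyl without a measurable effect on the read-out, whereas a substituent on the saturated chain carbon can move the number well beyond the scatter, as in a 15-fold lower number from compound 1 to compound 3 (1.19 log units; beyond the scatter). Nothing available explains this result.

The compounds shown leave open whether allyloxycarbonyl would read the same way on the isopropyl-bearing chain of compound 3, where the number is far lower and a difference might show more clearly. They also leave open whether a benzyl group on this oxygen, or a primary amide in place of the carboxy, would stay within the scatter of compound 1 as allyl does.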